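Pyrrolidin-1-yl for piperidin-1-yl: working notes on the series

The compounds below may be only part of what the source reports. "The series", "measured", "known", "first", "only" and "open" are said of these compounds alone.

Measured so far:
- compound 1 (`O=C(O)Cc1cn(CC(O)CN2CCCC2)c2ccccc12`) : 720 nM as a number
- compound 2 (`O=C(O)CCc1cn(CC(O)CN2CCCCC2)c2ccccc12`) : > 10000 nM as a limit

In a functional assay on HeLa cells (Homo sapiens) for inhibition, read by MTT assay, with a stated time of 72 h (on this read-out higher numbers stand for weaker inhibition and lower numbers for stronger inhibition), compound 2 gives > 10000 nM as a limit and not a number. Compound 3 (`O=C(O)CCc1cn(CC(O)CN2CCCC2)c2ccccc12`) differs from compound 2 by pyrrolidin-1-yl in place of piperidin-1-yl on a saturated chain carbon, two bonds along the chain from an oxygen on a saturated carbon and by nothing else. Compound 1 also carries pyrrolidin-1-yl and gives 720 nM in this assay as a measured number. The step expected is an at least 4.0-fold lower number from compound 2 to compound 3 (0.60 log units; beyond the scatter) toward stronger inhibition and beyond the usual scatter. Compound 3 is estimated at 2500 nM with an expected range from 400 nM to 10000 nM in this read-out.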

Compound 3, half-maximal inhibitory concentration: 4950 nM
Beside the measured number, compound 3's estimate is 2.0-fold (0.30 log units) below it; the measured number falls inside the stated range.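

In this assay, pyrrolidin-1-yl in place of piperidin-1-yl gives an at least 2.0-fold lower number from compound 2 to compound 3 (0.30 log units; that floor lies within the scatter), so this change now has a measured number on one side, though its floor does not clear the scatter. Compound 2 gives a limit and not a number, so the full size of the step stays unread: the limit of > 10000 nM in this assay, at which 1 of the 3 values shown sits. With pyrrolidin-1-yl held, carboxymethyl in place of carboxy gives a 6.9-fold higher number from compound 1 to compound 3 (0.84 log units; beyond the scatter), so the acid-bearing chain also matters here.

Open, on these data alone, is whether morpholin-4-yl in that place would track pyrrolidin-1-yl or piperidin-1-yl, and whether an amide in place of the carboxylic acid would hold the activity of compound 1.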